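The source may hold more compounds than are shown below. What is called first, only, known or untested is meant among the compounds shown, and "the series" means these compounds.

Measured compounds:
Compound 1 `O=c1cc(-c2ccccc2)oc2ccc(N3COc4c(Br)cc(Br)cc4C3)cc12` gives 16.1% in a functional assay on MCF7 cells (Homo sapiens) for inhibition, read by MTT assay, with a stated time of 48 h, tested at 30 ug/mL; on this read-out higher numbers stand for more inhibition of growth at the one concentration tested and lower numbers for less inhibition of growth.
Compound 2 `O=c1cc(-c2ccccc2)oc2ccc(N3COc4ccccc4C3)cc12` gives 68.5% in this assay.

Of the two measured compounds, compound 2 stands higher in this assay, and the gap between compound 2 and compound 1 lies beyond the usual scatter of this measurement. Going by the values given here, compound 1 is the only other measured compound, and no single-point step between the two has been worked out, so the comparison rests on the two values alone.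

Compound 3 `O=c1cc(-c2ccccc2)oc2ccc(N3COc4c(Br)cccc4C3)cc12` has not yet been measured. It differs from compound 2 in one place: bromo in place of hydrogen on an aromatic carbon. Compound 1 carries a related change on the same ring and sits far below compound 2. On that basis a fall from compound 2 to compound 3 is expected in this assay, of a size beyond the scatter but probably smaller than the gap between compound 2 and compound 1, since compound 3 keeps more of compound 2 intact. The expected step is a number 28.5 percentage points lower from compound 2 to compound 3 (beyond the scatter). Compound 3 is therefore estimated at 40%, within a range from 18% to 62%.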

Compound 3, percent growth inhibition at one concentration: 71.6%
Compound 3: the middle estimate sits 31.6 percentage points below what was measured; the whole stated range lies below it.
By their numbers in this assay, from the lowest: compound 1; then compounds 2 and 3 (each within the scatter of the next).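

In this assay, bromo in place of hydrogen on this aromatic carbon, ortho to a fused ring and meta to a fused ring, gives a number 3.1 percentage points higher from compound 2 to compound 3 (within the scatter), so a bromo at this position is tolerated on this read-out and does not by itself bring the fall that compound 1 had suggested. The large gap appears only with the further bromo of compound 1: hydrogen in place of bromo on an aromatic carbon gives a number 55.5 percentage points higher from compound 1 to compound 3 (beyond the scatter), which ties the low number of compound 1 to that second position or to the presence of both bromo groups together, and the three compounds do not separate these two readings. Nothing available gives a reason for either step.

Going by these compounds, it remains open whether chloro, methoxy or an amine on the same aromatic carbon would also hold the read-out level with compound 2, or whether the tolerance is special to bromo. Also open, on these data alone, is whether bromo alone at the other position of compound 1 would bring the whole gap, and what a carboxylic acid at either position would do.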